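Chain length and amine substitution on a fluoroindole inhibitor series

A few compounds are considered here, and "the series" means these few. Any claim that something is new, unique, unknown or untested is made for them only; others in the source may bear on it.

Of the compounds shown here, three sharing one core have been measured in an assay on urine for inhibition of Myeloperoxidase (Homo sapiens); on this read-out lower numbers stand for stronger inhibition and higher numbers for weaker inhibition. Compound 1 `CN1CCN(Cc2c[nH]c3ccc(F)cc23)CC1` gives 1000 nM. Compound 2 `CNCCCc1c[nH]c2ccc(F)cc12` gives 200 nM, and compound 3 `CCNCCCc1c[nH]c2ccc(F)cc12` gives 300 nM. Among these three numbers compound 3 stands second highest; its nearest neighbour is compound 2, while compound 1 lies furthest away, beyond the scatter.

Compound 4 `NCCCCc1c[nH]c2ccc(F)cc12` is the next candidate. Compared with compound 3, the difference is aminomethyl in place of ethylamino on a saturated chain carbon, three bonds along the chain from an aromatic carbon: the chain grows by one carbon and the nitrogen at its end carries hydrogens only.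

Among the measured compounds shown here, only one measured step bears on this change. Between compound 2 and compound 3 the only difference is a methyl added to the chain carbon bound to the amine nitrogen, and that gave a 1.5-fold higher number from compound 2 to compound 3 (0.18 log units; within the scatter). Removing such a substituent from the nitrogen therefore promises little movement on its own. For the measured compounds named here, no measured pair shows the effect of lengthening the chain, so that part of the change is untested.

On this basis compound 4 is expected to show a 1.2-fold lower number from compound 3 to compound 4 (0.08 log units; within the scatter), with no step beyond the scatter. The estimate for compound 4 in this assay is 250 nM, within a range from 90 nM to 700 nM.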

Compound 4, half-maximal inhibitory concentration: 15 nM
Compound 4: middle estimate off by 17-fold (1.22 log units), on the high side, outside the stated range (below it).
By their numbers in this assay, from the lowest: compound 4; then compounds 2 and 3 (each within the scatter of the next); then compound 1.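

Swapping the end of the chain turns out to matter far more than the earlier compounds suggested: aminomethyl in place of ethylamino gives a 20-fold lower number from compound 3 to compound 4 (1.30 log units; beyond the scatter), and aminomethyl in place of methylamino gives a 13-fold lower number from compound 2 to compound 4 (1.12 log units; beyond the scatter). The earlier step (a 1.5-fold higher number from compound 2 to compound 3 (0.18 log units; within the scatter)) showed only that methylamino and ethylamino ends on the same chain cannot be told apart in this assay, whereas these two new steps show that this part of the molecule can move the number well beyond the scatter. No available evidence bears on this result, so the large drop remains an observation without an explanation.

Compound 4 differs from compound 2 and compound 3 in both chain length and the substitution on the nitrogen, so these steps cannot say how much of the drop belongs to each change. A 3-aminopropyl chain on the shared core would test the unsubstituted amine at the shorter length, a 4-(methylamino)butyl chain would test the longer chain with a substituted amine, and a 5-aminopentyl chain would show whether further lengthening continues the trend.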